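The source may report more compounds than this note shows. Statements on the series, on what has been measured and on what is new or still open speak of the compounds shown alone.

Measured compounds:
- compound 1 `CN(C)CCCn1nc(Cc2nnc(SCCCCCCCC(=O)Nc3ccc(Cl)cc3Cl)n2C)c2ccccc2c1=O` — 3200 nM
- compound 2 `Cn1c(Cc2nn(CCC=O)c(=O)c3ccccc23)nnc1SCCCCCCCC(=O)Nc1ccc(Cl)cc1Cl` — 11700 nM

Among the compounds with values here, only two numbers are known in an assay on 32D cells for inhibition of interleukin-15 (Mus musculus), read by resazurin assay, with stated times of 30 min and 2.5 days, in the presence of a further agent that is not named here; a lower number here means a stronger inhibitor, a higher number a weaker inhibitor. Within the data shown here, compound 2 carries the higher of the two; the one step known, a 3.7-fold higher number from compound 1 to compound 2 (0.56 log units; beyond the scatter), separates it from compound 1.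

Compound 3 `Cn1c(Cc2n[nH]c(=O)c3ccccc23)nnc1SCCCCCCCC(=O)Nc1ccc(Cl)cc1Cl` is not yet measured. It differs from compound 2 by hydrogen in place of 2-formylethyl on an aromatic nitrogen. Among the measured compounds shown here, no measured pair covers this change. The nearest guide is the step from compound 1 to compound 2, where one chain end was exchanged for another on the same nitrogen and the number moved by a 3.7-fold higher number from compound 1 to compound 2 (0.56 log units; beyond the scatter), a modest step. Removing the chain altogether is a change of a different kind, so the expected size is taken as modest at most and the direction as uncertain, with a fairly wide range around the value of compound 2.

For compound 3 the estimated step of a 1.5-fold lower number from compound 2 to compound 3 (0.17 log units; within the scatter) in this assay is therefore small. Compound 3 is expected to give about 8000 nM in this assay, within a range of 2000 nM to 30000 nM.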

Compound 3, half-maximal inhibitory concentration: > 30000 nM
Compound 3: no number, only a limit (the forecaster's own chance of this, stated with the estimate: 15%); middle value at least 3.7-fold (0.57 log units) from the limit.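

In this assay compound 3, which has hydrogen on the aromatic nitrogen, gives no number, only a limit of the assay: the limit of > 30000 nM in this assay, at which 1 of the 3 values shown sits. Taking away the 2-formylethyl group gives an at least 2.5-fold higher number from compound 2 to compound 3 (0.40 log units; beyond the scatter), and taking away the 3-(dimethylamino)propyl group gives an at least 9.3-fold higher number from compound 1 to compound 3 (0.97 log units; beyond the scatter). The earlier pair varied only the end of the chain, whereas this result shows that the complete loss of the chain from this nitrogen moves the number upward from both chain-bearing compounds, with the true size of each step unknown beyond its printed bound.

As far as these compounds go, with only a dimethylamino end and a formyl end to compare, it remains open how much depends on the chain itself and how much on the group at its end. A carboxylic acid, a hydroxyl or a morpholine at the end of the chain, or a plain methyl or a longer chain on the same nitrogen, would help to separate these two contributions.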